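A few compounds are considered here, and "the series" means these few. Any claim that something is new, unique, unknown or untested is made for them only; others in the source may bear on it.

Measured in a functional assay on HT-1080 cells (Homo sapiens) for antiproliferative activity, read by sulforhodamine B assay, with a stated time of 48 h; a lower number here means a stronger inhibitor, a higher number a weaker inhibitor:

compound 1 `CC(=O)Nc1ccc(S(=O)(=O)Oc2ccccc2I)cc1` — 17000 nM
compound 2 `CC(C)C(=O)Nc1ccc(S(=O)(=O)Oc2ccccc2I)cc1` — 3300 nM
compound 3 `CC(C)(C)C(=O)Nc1ccc(S(=O)(=O)Oc2ccccc2I)cc1` — 2600 nM

Compound 3 gives the lowest number of the three in this assay, but its gap to compound 2 is small: a 1.3-fold lower number from compound 2 to compound 3 (0.10 log units; within the scatter). For the measured compounds named here, only the step from compound 1 sets it clearly apart: a 6.5-fold lower number from compound 1 to compound 3 (0.82 log units; beyond the scatter), alongside a 5.2-fold lower number from compound 1 to compound 2 (0.71 log units; beyond the scatter).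

Compound 4 `O=C(CCl)Nc1ccc(S(=O)(=O)Oc2ccccc2I)cc1` differs from compound 3 in one place: chloromethyl in place of tert-butyl on a carbonyl carbon. The three measured steps all concern the group on this same carbonyl carbon, and they show that methyl gave the highest number, while isopropyl and tert-butyl gave modestly lower values that did not differ beyond the scatter. Going by the values given here, no measured compound carries chlorine at this position, so the effect of the chloromethyl group itself is unknown. Since the smaller group in compound 1 gave a higher number, as a 6.5-fold lower number from compound 1 to compound 3 (0.82 log units; beyond the scatter) shows, compound 4 is expected to move upward from compound 3, with the step estimated at a 2.3-fold higher number from compound 3 to compound 4 (0.36 log units; beyond the scatter). Compound 4 is therefore estimated at 6000 nM, in a range from 1500 nM to 24000 nM.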

Compound 4, half-maximal inhibitory concentration: 600 nM
Beside the measured number, compound 4's estimate is 10-fold (1.00 log units) above it, outside the stated range (below it).
By their numbers in this assay, from the lowest: compound 4; then compounds 3 and 2 (each within the scatter of the next); then compound 1.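

In this assay, methyl had given a higher number than isopropyl and tert-butyl, but chloromethyl breaks that pattern, going lower than both larger groups (a 4.3-fold lower number from compound 3 to compound 4 (0.64 log units; beyond the scatter); a 5.5-fold lower number from compound 2 to compound 4 (0.74 log units; beyond the scatter)). So the size of the group on this carbonyl carbon does not alone set the number, and the change with the largest effect here is chloro in place of hydrogen on the saturated chain carbon bound to that carbonyl carbon (a 28-fold lower number from compound 1 to compound 4 (1.45 log units; beyond the scatter)). Nothing measured here explains why this chlorine lowers the number.

The compounds shown leave open whether this drop is specific to chlorine or would also appear with bromomethyl, fluoromethyl or aminomethyl on the same carbonyl carbon. They also leave open whether chlorine placed further out on a longer chain would give a similar number.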